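Cytotoxicity on L6 cells: ester variation in a bicyclic series

This account rests on a few compounds, and the source may have more. Where it says the series, first, only, none or still open, it means among the compounds named here.

Measured so far:
compound 1, `CCN(CC)CC(=O)OC1CC2(N(C)C)CC(c3ccccc3)C1C(c1ccccc1)C2`: 30100 nM
compound 2, `CCN(CC)CC(=O)OC1CC2(N3CCCCC3)CC(c3ccccc3)C1C(c1ccccc1)C2`: 23900 nM

Both compounds were run in an ADME assay on L6 cells (Rattus norvegicus) for cytotoxicity, with a stated time of 72 h; on this read-out higher numbers stand for weaker inhibition and lower numbers for stronger inhibition. Going by the values given here, compound 2 gives 23900 nM, the lowest of the two numbers, but its only neighbour is compound 1, and the step of a 1.3-fold lower number from compound 1 to compound 2 (0.10 log units; within the scatter) lies within the scatter, so the two numbers are not distinguishable. That step exchanges the amine on the saturated ring carbon and leaves the ester untouched.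

Compound 3, `O=C(/C=C/c1ccccc1)OC1CC2(N3CCCCC3)CC(c3ccccc3)C1C(c1ccccc1)C2`, keeps the piperidin-1-yl of compound 2 and changes the ester side instead: 2-phenylethenyl in place of (diethylamino)methyl on a carbonyl carbon. Among the compounds with values here, no measured step touches this part of the core; the single step known concerns another place and was within the scatter, so it gives no direction for the ester change. The expectation for compound 3 in this assay therefore rests on compound 2 alone, with a wide range to cover the unknown effect of the new group.

Compound 3 is estimated at 24000 nM, with a range from 7000 nM to 80000 nM, meaning an expected step of a 1.0-fold higher number from compound 2 to compound 3 (0.00 log units; within the scatter).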

Compound 3, half-maximal inhibitory concentration: 10500 nM
The estimate for compound 3 lay 2.3-fold (0.36 log units) above the measured number, and the stated range covers the measured number.
By their numbers in this assay, from the lowest: compound 3; then compounds 2 and 1 (each within the scatter of the next).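

In this assay, going by these compounds alone, the ester position gives the first step beyond the scatter: a 2.3-fold lower number from compound 2 to compound 3 (0.36 log units; beyond the scatter) is modest but readable, whereas the amine exchange on the saturated ring carbon, a 1.3-fold lower number from compound 1 to compound 2 (0.10 log units; within the scatter), is not. The change replaces (diethylamino)methyl, with its nitrogen and hydrogen-bond acceptor and no ring, by the all-carbon 2-phenylethenyl, with one six-membered aromatic ring and a double bond outside it, so this one step alters several features together and cannot assign the lower number to any one of them. Nothing available bears on why the number moved at this position.

Still open, from the compounds shown here alone, is which part of the new group carries the step: a saturated 2-phenylethyl group would test the double bond, while a phenyl group placed directly on the carbonyl carbon would test the two-carbon link. Also open, going by these compounds, is whether the ester step holds with another amine, which 2-phenylethenyl paired with dimethylamino on the saturated ring carbon would show.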